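A few compounds are considered here, and "the series" means these few. Any claim that something is new, unique, unknown or untested is made for them only; others in the source may bear on it.

Of the compounds shown here, three with a shared core have been measured in an in vitro assay on SH-SY5Y cells for displacement of a labelled ligand from Neuronal acetylcholine receptor; alpha3/beta4 (Homo sapiens); on this read-out higher numbers stand for weaker inhibition and lower numbers for stronger inhibition. Compound 1 `CN1C[C@H]2C=C(c3cccnc3)C[C@H](C2)C1` gives 534 nM, compound 2 `CN1CC2C=C(c3ccc(Cl)nc3)CC(C2)C1` gives 986 nM, and compound 3 `Fc1ccc(C2=CC3CNCC(C2)C3)cn1` gives 28 nM. Compound 2 stands with the highest number of the three; its nearest neighbour is compound 1, whose number lies within the usual scatter of compound 2, so no order between these two can be read. Compound 3, the furthest, gives a number that is lower by a margin well beyond the scatter.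

Compound 4 `COc1cc(C2=CC3CC(C2)CN(C)C3)cnc1Cl` has not yet been measured. It differs from compound 2 in one place: methoxy in place of hydrogen on an aromatic carbon. Going by the values given here, no pair of measured compounds shows a step of this kind, so nothing in the numbers at hand tells how such a change acts in this assay . A step from compound 2 to compound 4 of a 1.1-fold higher number from compound 2 to compound 4 (0.05 log units; within the scatter) is expected, that is, at most a modest move in either direction and most likely none beyond the scatter. For compound 4 in this assay the estimate is 1100 nM, expected between 400 nM and 3500 nM.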

Compound 4, inhibition constant: 1430 nM
Compound 4: middle estimate off by 1.3-fold (0.11 log units), on the low side; low and high end bracket the measured number.
By their numbers in this assay, from the lowest: compound 3; then compounds 1, 2 and 4 (each within the scatter of the next, the first and the last beyond it).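

In this assay, methoxy in place of hydrogen on an aromatic carbon, ortho to a chloro group and two atoms from the ring nitrogen, gives a 1.5-fold higher number from compound 2 to compound 4 (0.16 log units; within the scatter) and so no change that can be read. Going by these compounds alone, this is the first step of its kind in the set, and it shows that this position of compound 2 can carry a methoxy group without a move beyond the scatter. Nothing at hand offers a reason for this outcome.

From the compounds shown here alone, it remains open whether another group at this position, such as a hydroxyl, an amine or an ethoxy, would behave the same way. Going by these compounds, it is also open whether methoxy would give a similar step without the chloro group, on the ring of compound 1.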